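The compounds below may be only part of what the source reports. "The series", "measured", "known", "first", "only" and "open" are said of these compounds alone.

Compound 2 `CC(C)c1ccc(Nc2nc(SCc3cn(CC(=O)NC(=O)Nc4ccccn4)nn3)nc(-c3ccc(C(C)C)cc3)c2C#N)cc1`: 2490 nM in a functional assay on ECa-109 cells (Homo sapiens) for inhibition, read by MTT assay, with a stated time of 72 h; a lower number here means a stronger inhibitor, a higher number a weaker inhibitor
Compound 1 `CC(C)c1ccc(-c2nc(SCc3cn(CC(=O)NC(=O)Nc4ccccn4)nn3)nc(Nc3ccc(F)cc3)c2C#N)cc1`: a limit in this assay, > 64000 nM

For the measured compounds named here, compound 2 holds the only number in this assay; the other value is a limit (the limit of > 64000 nM in this assay, at which 1 of the 2 values shown sits). Going by the values given here, the one measured step, an at least 25-fold lower number from compound 1 to compound 2 (1.40 log units; beyond the scatter), put isopropyl in place of fluoro on an aromatic carbon. Compound 3 `CC(C)c1ccc(Nc2nc(SCc3cn(CC(=O)NC(=O)Nc4ccccn4)nn3)nc(-c3ccc(Cl)cc3)c2C#N)cc1` carries chloro in place of isopropyl on an aromatic carbon, which takes the isopropyl away again, though chloro is not fluoro. A weakening is therefore expected, smaller than that measured step. The step from compound 2 to compound 3 is estimated as a 6.0-fold higher number from compound 2 to compound 3 (0.78 log units; beyond the scatter). Compound 3 is expected near 15000 nM, between 4000 nM and 60000 nM.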

Compound 3, half-maximal inhibitory concentration: > 64000 nM
Compound 3: only a limit was reported; the forecaster's own chance of this, stated with the estimate: 25%; middle value at least 4.2-fold (0.63 log units) from the limit.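

Isopropyl counts at this second site too: going from 4-isopropylphenyl to 4-chlorophenyl gives an at least 25-fold higher number from compound 2 to compound 3 (1.40 log units; beyond the scatter), whereas the earlier step changed the other aromatic ring. Of the three compounds, only compound 2, with an isopropyl on both rings, gives a number in this assay. Compound 3, like compound 1, stands only at a limit, and the full size of the loss cannot be read:  the limit of > 64000 nM in this assay, at which 2 of the 3 values shown sit.

The compounds shown leave open whether another group at this place, such as a methyl, a tert-butyl or a methoxy, would keep a measurable number.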